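The source may report more compounds than this note shows. Statements on the series, on what has been measured and on what is new or still open speak of the compounds shown alone.

Compound 1, `COc1ccc(/C=C2\CCC=CC2=O)cc1`, is the starting point of this series. In a functional assay on MCF7 cells (Homo sapiens) for antiproliferative activity, read by sulforhodamine B assay, with a stated time of 72 h (on this read-out higher numbers stand for weaker inhibition and lower numbers for stronger inhibition), compound 1 gives 2570 nM. Compound 2, `COc1ccc(/C=C2\CCC=CC2=O)c(C)c1`, carries one change from it, (methyl in place of hydrogen on an aromatic carbon), and in this assay compound 2 gives 1840 nM; the step is a 1.4-fold lower number from compound 1 to compound 2 (0.15 log units; within the scatter). Compound 3, `COc1cc(/C=C2\CN(S(=O)(=O)c3ccccc3)C=CC2=O)cc(OC)c1OC`, is built on a different core, and the difference between the two cores is not broken down here. In this assay compound 3 reaches only a limit, > 25000 nM. That limit is described by the limit of > 25000 nM in this assay, at which 1 of the 3 values shown sits.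

Compound 4, `COc1cc(/C=C2\CN(S(=O)(=O)c3ccc(C)cc3)C=CC2=O)cc(OC)c1OC`, has not been measured. It differs from compound 3 by methyl in place of hydrogen on an aromatic carbon, which is the same kind of change as that from compound 1 to compound 2, though its place differs: in compound 2 the methyl sits ortho to a group of 8 heavy atoms and meta to a methoxy group, in compound 4 para to a large group. Since the step from compound 1 to compound 2 lay within the scatter, compound 4 is expected to change little from compound 3, a step that the limit leaves unreadable from compound 3 to compound 4. Compound 4 is therefore estimated at 30000 nM, roughly between 12000 nM and 80000 nM, most likely again reported only as a limit.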

Compound 4, half-maximal inhibitory concentration: 19200 nM
Beside the measured number, compound 4's estimate is 1.6-fold (0.19 log units) above it, and the stated range covers the measured number.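

Replacing phenyl with 4-methylphenyl on the sulfonyl group gives, in this assay, an at least 1.3-fold lower number from compound 3 to compound 4 (0.11 log units; that floor lies within the scatter). This step starts from a limit and not from a number: the limit of > 25000 nM in this assay, at which 1 of the 4 values shown sits. The methyl change can therefore be set side by side on two cores, but this does not show that it carries over from one core to the other with the same size, nor that its size differs between them: the same change on two cores in this assay, a 1.4-fold lower number (0.15 log units; within the scatter) from compound 1 to compound 2 and an at least 1.3-fold lower number (0.11 log units; that floor lies within the scatter) from compound 3 to compound 4; the limit leaves it open whether they differ.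

The compounds shown leave open what a group other than methyl would do at this place on the ring of the phenylsulfonyl group, for instance an amine, a carboxylic acid or a longer chain. They also leave open whether such a group would bring the core of compound 3 off its limit and give a step that can be read in full in this assay.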